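Working notes: sulfonyl tail variation, compounds 1 to 4

This account rests on a few compounds, and the source may have more. Where it says the series, first, only, none or still open, it means among the compounds named here.

Compound 1, `O=C(NCC1CCN(CCCS(=O)(=O)N2CCNCC2)CC1)c1cccc2c1OCCO2`: in an assay on isolated protein for inhibition of 5-hydroxytryptamine receptor 4 (Homo sapiens) (on this read-out lower numbers stand for stronger inhibition and higher numbers for weaker inhibition), compound 1 gives 0.159 nM.
Compound 2, `O=C(NCC1CCN(CCCS(=O)(=O)N2CCOCC2)CC1)c1cccc2c1OCCO2`: in this assay compound 2 gives 0.398 nM.
Compound 3, `CC(C)S(=O)(=O)N1CCN(S(=O)(=O)CCCN2CCC(CNC(=O)c3cccc4c3OCCO4)CC2)CC1`: in this assay compound 3 gives 0.126 nM.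

Compound 3 has the lowest number of the three. Its gap to compound 1 is small, a 1.3-fold lower number from compound 1 to compound 3 (0.10 log units; within the scatter), so the two stand within the scatter of each other; its gap to compound 2 is larger, a 3.2-fold lower number from compound 2 to compound 3 (0.50 log units; beyond the scatter). The remaining step, a 2.5-fold higher number from compound 1 to compound 2 (0.40 log units; beyond the scatter), separates compounds 1 and 2 beyond the scatter.

Compound 4, `CCCS(=O)(=O)N1CCN(S(=O)(=O)CCCN2CCC(CNC(=O)c3cccc4c3OCCO4)CC2)CC1`, has not yet been measured. It differs from compound 3 in one place: propyl in place of isopropyl on a sulfonyl sulfur. Among the compounds with values here, no measured step touches the group on that sulfonyl sulfur. The nearest information is a 1.3-fold lower number from compound 1 to compound 3 (0.10 log units; within the scatter), where putting the whole isopropylsulfonyl onto the ring nitrogen moved the number only within the scatter. If the entire group is nearly neutral, reshaping its three carbons is expected to matter even less, and no step beyond the scatter is expected in this assay.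

Compound 4 is therefore estimated at 0.14 nM, with a range from 0.07 nM to 0.3 nM. The expected step is a 1.1-fold higher number from compound 3 to compound 4 (0.05 log units; within the scatter).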

Compound 4, inhibition constant: 0.1 nM
The estimate for compound 4 lay 1.4-fold (0.15 log units) above the measured number; low and high end bracket the measured number.
By their numbers in this assay, from the lowest: compounds 4, 3 and 1 (each within the scatter of the next); then compound 2.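

Swapping isopropyl for propyl on the sulfonyl sulfur gives the step of a 1.3-fold lower number from compound 3 to compound 4 (0.10 log units; within the scatter) and so adds a direct comparison at this position: in this assay, these two groups of three carbons cannot be told apart. Propylsulfonyl in place of hydrogen on the ring nitrogen gives a 1.6-fold lower number from compound 1 to compound 4 (0.20 log units; within the scatter) and so behaves as isopropylsulfonyl did, making two sulfonyl groups at this nitrogen that stay within the scatter of compound 1. The step of a 4.0-fold lower number from compound 2 to compound 4 (0.60 log units; beyond the scatter) widens the morpholin-4-yl comparison to a second substituted piperazin-1-yl compound, and compound 1, compound 3 and compound 4 all stand apart from compound 2 beyond the scatter.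

The compounds shown leave open whether a longer chain such as butyl, or a ring such as cyclopropyl or phenyl, on this sulfonyl sulfur would also stay within the scatter. They also leave open whether an acetyl group or a carboxylic acid on the ring nitrogen, in place of the whole sulfonyl group, would do the same.

Nothing at hand explains why these steps are as small or as large as they are.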